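The compounds below may be only part of what the source reports. "The series", "measured", "known", "first", "only" and "open" are said of these compounds alone.

In an ADME assay on microsomes from liver (Homo sapiens) for metabolic stability, read by LC-MS, using NADPH, with a stated time of 10 min, tested at 10 uM (on this read-out lower numbers stand for a shorter-lived compound and higher numbers for a longer-lived compound), three compounds have been measured:

compound 1 `Nc1ncnc2c1c(Oc1cc(C(F)(F)F)ccn1)nn2[C@H]1CC[C@@H](N)CC1`: > 2.41 h
compound 2 `Nc1ncnc2c1c(Oc1cc(O)ccn1)nn2C1CCC(F)(F)CC1`: > 2.41 h
compound 3 `Nc1ncnc2c1c(Oc1cccc(Cl)c1)nn2[C@H]1C[C@H](F)C1`: 0.153 h

The top of the scale here is the limit of > 2.41 h in this assay, at which 2 of the 3 values shown sit, and compound 1 stands there. Compound 1 reads > 2.41 h as a limit of the assay and not as a number, so its true half-life is not known. Compound 2 also reads > 2.41 h as a limit. Compound 3 gives 0.153 h as a true number, so a short half-life does occur among these compounds.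

The next compound to be measured is compound 4 `CO[C@H]1CC[C@H](n2nc(Oc3cc(C(F)(F)F)ccn3)c3c(N)ncnc32)CC1`, which keeps the core of compound 1 and changes one group: 4-methoxycyclohexyl in place of 4-aminocyclohexyl on an aromatic nitrogen and so the group that enters is a 4-methoxycyclohexyl with no hydrogen-bond donor. Within the data shown here, no measured pair shows what this swap does, so any forecast is rough. A moderate shortening is expected, and the estimated change is an at least 1.6-fold lower number from compound 1 to compound 4 (0.20 log units; that floor lies within the scatter) with real doubt about its size. The reading could well be only a limit again. Compound 4 is expected at 1.5 h with an estimated range from 0.4 h to 4 h as its likely span.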

Compound 4, half-life: > 2.41 h
Compound 4 ended at the assay's limit (the forecaster's own chance of this, stated with the estimate: 35%); at least 1.6-fold (0.20 log units) between middle value and limit.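

Compound 1 and compound 4 both read only as a limit and not as a number, so no step can be read for 4-methoxycyclohexyl in place of 4-aminocyclohexyl: the limit of > 2.41 h in this assay, at which 3 of the 4 values shown sit.

The compounds shown leave open the true half-life of each, and whether this swap changes it at all.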